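Ethoxy in Place of Trifluoromethyl on a Shared Core

A few compounds are considered here, and "the series" means these few. Any claim that something is new, unique, unknown or untested is made for them only; others in the source may bear on it.

Of the compounds shown here, two have been measured in an assay on brain for binding affinity to Neuronal acetylcholine receptor; alpha4/beta2 (Rattus norvegicus), read by radioligand binding; on this read-out lower numbers stand for stronger inhibition and higher numbers for weaker inhibition. Compound 1 `Cc1ccc(OC[C@@H]2CCN2)cn1` gives 0.057 nM. Compound 2 `FC(F)(F)c1cncc(OC[C@@H]2CCN2)c1` gives 0.49 nM, the higher of the two numbers, and its gap to compound 1 lies beyond the usual scatter, so compound 2 is the weaker binder of the pair. Compound 3 `CCOc1cncc(OC[C@@H]2CCN2)c1` has not yet been measured. It differs from compound 2 in a single place: ethoxy in place of trifluoromethyl on an aromatic carbon. Among the measured compounds shown here, no measured pair is separated by this same change, so any expectation rests on the two values alone. Since compound 2, which carries the trifluoromethyl, gives 0.49 nM while compound 1 gives 0.057 nM, a step toward a lower number is expected in this assay, estimated as a 4.1-fold lower number from compound 2 to compound 3 (0.61 log units; beyond the scatter). Compound 3 is expected to give about 0.12 nM, within a range from 0.03 nM to 0.5 nM.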

Compound 3, inhibition constant: 0.039 nM
Beside the measured number, compound 3's estimate is 3.1-fold (0.49 log units) above it, and the stated range covers the measured number.
By their numbers in this assay, from the lowest: compounds 3 and 1 (each within the scatter of the next); then compound 2.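

In this assay putting ethoxy in place of trifluoromethyl on this aromatic carbon gives a 13-fold lower number from compound 2 to compound 3 (1.10 log units; beyond the scatter) and is a large step. Among the compounds shown here, compounds 1 and 2 differ in more than one place, so this is the first pair to isolate a single group, and it shows that the group at this position, two atoms from the ring nitrogen, strongly affects the number with the rest of the structure unchanged. The change swaps several things at once, including the atoms present and the hydrogen-bond acceptor count, so one step cannot show which of these matters.

Nothing measured here explains the size of this step. As far as these compounds go, whether a longer chain such as propoxy, or an amine, at this position would also give a low number remains open.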